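The source may hold more compounds than are shown below. What is called first, only, known or untested is meant among the compounds shown, and "the series" means these compounds.

Compound 2 `Cc1nn(-c2ncnc3nc[nH]c23)c2c1C(OCc1ccccc1C#N)CC(=O)N2` is the reference point here. Among the measured compounds shown here, in a functional assay on HEK293 cells for agonist activity at G-protein coupled receptor 39 (Homo sapiens), read by scintillation proximity assay and inositol phosphate accumulation, with a stated time of 75 min, in the presence of a further agent that is not named here (on this read-out lower numbers stand for an effect already at smaller amounts and higher numbers for an effect only at larger amounts of compound), compound 2 gives 8 nM, the second highest of the three numbers measured so far. Compound 1 `Cc1nn(-c2ncnc3nc[nH]c23)c2c1C(C(=O)Nc1ccccc1)CC(=O)N2` gives 10 nM, and the step of a 1.3-fold lower number from compound 1 to compound 2 (0.10 log units; within the scatter) lies within the scatter. Compound 3 `Cc1nn(-c2ncnc3nc[nH]c23)c2c1C(NC(=O)Cc1cccs1)CC(=O)N2` gives 3 nM; the step of a 2.7-fold lower number from compound 2 to compound 3 (0.43 log units; beyond the scatter) is beyond the scatter, as is a 3.3-fold lower number from compound 1 to compound 3 (0.52 log units; beyond the scatter). All three measured steps exchange the whole group on the saturated ring carbon, each for a group of a different kind.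

Compound 4 `Cc1nn(-c2ncnc3nc[nH]c23)c2c1C(OCC(C)C)CC(=O)N2` keeps the ether linkage of compound 2 and differs only at its far end: isopropyl in place of 2-cyanophenyl on a saturated chain carbon bound to an oxygen on a saturated carbon. For the measured compounds named here, no measured step changes only the distal part of a substituent while keeping the linkage to the saturated ring carbon, so none of the three steps bears directly on this change; they show only that exchanging the group at this position moves the number in this assay by modest amounts at most. For compound 4 a modest step, or none beyond the scatter, is therefore expected, with a somewhat higher number considered slightly more likely than a lower one. The estimate for compound 4 in this assay is 15 nM, with a range from 5 nM to 50 nM. The expected step is a 1.9-fold higher number from compound 2 to compound 4 (0.27 log units; within the scatter).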

Compound 4, half-maximal effective concentration: 4 nM
Compound 4: middle estimate off by 3.8-fold (0.57 log units), on the high side; the whole stated range lies above it.
By their numbers in this assay, from the lowest: compounds 3, 4, 2 and 1 (each within the scatter of the next, the first and the last beyond it).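

In this assay, exchanging 2-cyanophenyl for isopropyl at the far end of the ether gives no step beyond the scatter (a 2.0-fold lower number from compound 2 to compound 4 (0.30 log units; within the scatter)), so within this pair neither the aromatic ring nor the nitrile of the 2-cyanobenzyl group is needed for a number in this range. The isobutoxy group also stands level with the (((thiophen-2-yl)methyl)carbonyl)amino group within the scatter (a 1.3-fold higher number from compound 3 to compound 4 (0.12 log units; within the scatter)), and it joins that group in lying beyond the scatter from phenylcarbamoyl (a 2.5-fold lower number from compound 1 to compound 4 (0.40 log units; beyond the scatter)), whereas the (2-cyanobenzyl)oxy group of compound 2 does not. No supporting data are available to account for these steps.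

On these data alone, whether the ether oxygen itself contributes remains open, and a plain pentyl chain on the saturated ring carbon in place of isobutoxy would address that. Also open, as far as these compounds go, is how far the far end of the ether tolerates change, for example a longer chain, an amine or a carboxylic acid in place of isopropyl.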